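From a fluorinated ring to a plain chain

The source may report more compounds than this note shows. Statements on the series, on what has been measured and on what is new or still open speak of the compounds shown alone.

Measured in a functional assay on DLD-1 cells (Homo sapiens) for cytotoxicity, read by MTT assay, with a stated time of 48 h; a lower number here means a stronger inhibitor, a higher number a weaker inhibitor:
- compound 1 `CN(C)CCNc1ccnc2cc(OCc3ccc(F)cc3)ccc12`: 810 nM
- compound 2 `Fc1ccc(COc2ccc3c(Cl)ccnc3c2)cc1`: 3230 nM

Compound 1 holds the lower of these two numbers, which makes it the stronger inhibitor of the pair. Compound 3 `CCCCCCOc1ccc2c(NCCN(C)C)ccnc2c1` has not been measured yet. It differs from compound 1 as follows: pentyl in place of 4-fluorophenyl on a saturated chain carbon bound to an oxygen on an aromatic ring. Among the compounds with values here, no measured step touches this place. The only one, a 4.0-fold higher number from compound 1 to compound 2 (0.60 log units; beyond the scatter), is a modest change made elsewhere on the molecule, with chloro in place of (2-(dimethylamino)ethyl)amino on an aromatic carbon. Compound 3 keeps that amino group, so this step offers no direct guide to its value, and any forecast remains uncertain. No clear shift in this assay is therefore expected, and the estimated change is a 1.2-fold higher number from compound 1 to compound 3 (0.09 log units; within the scatter). For compound 3 the expected value is 1000 nM, with an estimated range of 350 nM to 3000 nM.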

Compound 3, half-maximal inhibitory concentration: 1870 nM
The estimate for compound 3 lay 1.9-fold (0.27 log units) below the measured number; the measured number falls inside the stated range.
By their numbers in this assay, from the lowest: compound 1; then compounds 3 and 2 (each within the scatter of the next).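

Within the data shown here, this is the first measured change at this position, and the position does register it: in this assay, swapping the 4-fluorophenyl for pentyl on the saturated chain carbon gives a 2.3-fold higher number from compound 1 to compound 3 (0.36 log units; beyond the scatter). The step is beyond the scatter but modest, so the ring is not required for cytotoxicity here: compound 3, with a plain chain and no ring, remains active, though less so than compound 1. Nothing available accounts for this difference.

This single step changes the ring, the fluorine and the shape of the group all at once, so it cannot show which of them matters. A plain benzyl group would test the fluorine on its own, while a butyl or octyl chain would show how the number follows chain length.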